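Benzamide without ring substituents on the pyrazole amide series

A few compounds are considered here, and "the series" means these few. Any claim that something is new, unique, unknown or untested is made for them only; others in the source may bear on it.

Compound 2 `COc1cc(-c2nn(-c3cccc(NC(=O)Nc4ccc(Cl)c(C(F)(F)F)c4)c3)cc2-c2ccncc2)ccc1Cl` has the lowest number among the two compounds measured in a functional assay on SF-268 cells (Homo sapiens) for inhibition, read by sulforhodamine B assay, with a stated time of 48 h (on this read-out lower numbers stand for stronger inhibition of growth and higher numbers for weaker inhibition of growth), where compound 2 gives 1460 nM. For the measured compounds named here, its nearest neighbour is compound 1 `COc1cc(-c2nn(-c3cccc(NC(=O)c4ccc(Cl)c(C(F)(F)F)c4)c3)cc2-c2ccncc2)ccc1Cl`, which in this assay gives 4860 nM; the only measured step, a 3.3-fold lower number from compound 1 to compound 2 (0.52 log units; beyond the scatter), shows the urea with a lower number than the corresponding amide. Compound 3 `COc1cc(-c2nn(-c3cccc(NC(=O)c4ccccc4)c3)cc2-c2ccncc2)ccc1Cl` is the next compound, not yet measured. It differs from compound 2 in one place: phenyl in place of (4-chloro-3-(trifluoromethyl)phenyl)amino on a carbonyl carbon. This change does two things at once, it turns the urea back into an amide and it strips the chlorine and trifluoromethyl from the ring. Going by the values given here, the step from compound 1 to compound 2 bears on the first part and suggests that returning to an amide should raise the number by a modest amount; no measured pair speaks to the loss of the ring substituents. Compound 3 is therefore expected to give a clearly higher number than compound 2, in this assay about 15000 nM, within a range of 4000 nM to 50000 nM, a step of a 10-fold higher number from compound 2 to compound 3 (1.01 log units; beyond the scatter).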

Compound 3, concentration for 50% growth inhibition: 859 nM
The estimate for compound 3 lay 17-fold (1.24 log units) above the measured number; the whole stated range lies above it.
By their numbers in this assay, from the lowest: compounds 3 and 2 (each within the scatter of the next); then compound 1.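

Within the amides, taking the chlorine and trifluoromethyl off the ring gives a 5.7-fold lower number from compound 1 to compound 3 (0.75 log units; beyond the scatter) in this assay and so shows for the first time that, on this carbonyl carbon, the substituted ring is not required for growth inhibition at this level and in the amide setting is the poorer of the two rings. Set against the urea, the plain benzamide gives a 1.7-fold lower number from compound 2 to compound 3 (0.23 log units; within the scatter) so compound 2 and compound 3 cannot be told apart, and the edge that the urea held over compound 1 is matched by an amide carrying an unsubstituted phenyl. Nothing given here explains why the substituted ring reads as it does in the amide.

Still open, going by these compounds, is whether chlorine alone or trifluoromethyl alone on the phenyl ring would read like compound 1 or like compound 3, and whether the urea linkage with an unsubstituted phenyl would differ from compound 3 at all. Also open, on these data alone, is how other groups on the same carbonyl carbon, such as a pyridyl or a cyclohexyl, would read in this assay on this shared core.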